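This account rests on a few compounds, and the source may have more. Where it says the series, first, only, none or still open, it means among the compounds named here.

Measured so far:
compound 1 `CNc1nc(SC)nc2c1ncn2[C@@H]1C[C@@H](O)[C@H](CO)O1`, which in a functional assay on B-95-8 cells (Cercopithecidae) with B-95-8 cell line (Saguinus oedipus) as the target (a higher number here means a weaker inhibitor, a lower number a stronger inhibitor), gives > 300 uM
compound 2 `Nc1nc(Br)nc2c1ncn2[C@@H]1C[C@@H](O)[C@H](CO)O1`, which in this assay gives 6 uM
compound 3 `CSc1nc(N(C)C)c2ncn([C@@H]3C[C@@H](O)[C@H](CO)O3)c2n1`, which in this assay gives 116 uM

The value of compound 1 is a limit of this assay and not a number, as shown by the limit of > 300 uM in this assay, at which 1 of the 3 values shown sits. Of the two numbers, compound 2 has the lowest; how the core of compound 1 differs from that of compound 2 is not broken down here. The change methyl in place of hydrogen on a nitrogen on an aromatic ring gave an at least 2.5-fold lower number from compound 1 to compound 3 (0.41 log units; beyond the scatter). Compound 4 `CNc1nc(Br)nc2c1ncn2[C@@H]1C[C@@H](O)[C@H](CO)O1` carries the same kind of change relative to compound 2, (methyl in place of hydrogen on a nitrogen on an aromatic ring); here the nitrogen's other neighbour is an aromatic carbon only, whereas in compound 1 the neighbours are an aromatic carbon and a saturated chain carbon, so the surroundings differ. The expected step of a 1.5-fold lower number from compound 2 to compound 4 (0.18 log units; within the scatter) rests on an at least 2.5-fold lower number from compound 1 to compound 3 (0.41 log units; beyond the scatter), tempered for the differing place. Compound 4 is therefore expected to give about 4 uM in this assay, with an expected range from 1 uM to 20 uM.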

Compound 4, concentration for 50% inhibition: 253 uM
Beside the measured number, compound 4's estimate is 63-fold (1.80 log units) below it, and the stated range ends below it.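

Methyl in place of hydrogen on a nitrogen on an aromatic ring did not carry over from one core to the other in this assay: the same change on two cores in this assay, an at least 2.5-fold lower number (0.41 log units; beyond the scatter) from compound 1 to compound 3 and a 42-fold higher number (1.62 log units; beyond the scatter) from compound 2 to compound 4, at least 100-fold (2.03 log units) apart, beyond the scatter of two such steps. For the compounds shown here, on the core of compound 2 the change gives a 42-fold higher number from compound 2 to compound 4 (1.62 log units; beyond the scatter), but two pairs show only that the step depends on the core, not why it does or whether this holds across the series. Compound 1 stands at a limit of the assay and not at a number: the limit of > 300 uM in this assay, at which 1 of the 4 values shown sits.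

Bromo in place of methylsulfanyl gives an at least 1.1-fold lower number from compound 1 to compound 4 (0.07 log units; that floor lies within the scatter), which leaves the order of the two open. Also open, from the compounds shown here alone, is how an ethyl group on that nitrogen, or chloro in place of bromo on the aromatic carbon, would read.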